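Compound 2 at the limit: what a new ring may do

This account rests on a few compounds, and the source may have more. Where it says the series, first, only, none or still open, it means among the compounds named here.

In a functional assay on DU-145 cells (Homo sapiens) for inhibition, read by trypan blue exclusion, with a stated time of 96 h (a higher number here means a weaker inhibitor of growth, a lower number a stronger inhibitor of growth), compound 1 `Cc1ccc(S/C(=C/c2ccc(F)c(C)c2)C(=O)c2ccc(Br)cc2)cc1` gives 25000 nM. Compound 2 `Cc1ccc(S/C(=C/c2ccc(N(C)C)cc2)C(=O)c2ccc(Br)cc2)cc1` gives > 100000 nM, which is a limit of the assay and not a number. Compound 2 therefore offers no exact starting point, only (the limit of > 100000 nM in this assay, at which 1 of the 2 values shown sits).

The next structure, compound 3 `Cc1ccc(S/C(=C/c2c(O)cc(O)cc2O)C(=O)c2ccc(Br)cc2)cc1`, keeps the shared core and changes one group: 2,4,6-trihydroxyphenyl in place of 4-(dimethylamino)phenyl on a double-bonded chain carbon bound to a double-bonded chain carbon. The group sits on a double-bonded chain carbon bound to a double-bonded chain carbon, the same place that differs between the two measured compounds. Among the compounds with values here, only one measured step bears on this change: an at least 4.0-fold higher number from compound 1 to compound 2 (0.60 log units; beyond the scatter). It shows that this place can move the read-out, though it says nothing directly about the hydroxyl-bearing ring that enters here. Compound 1, at 25000 nM, shows that a group in this place can bring a measurable number, so a weak but measurable result seems the likeliest outcome. Another limit remains quite possible. The estimated change is an at least 3.3-fold lower number from compound 2 to compound 3 (0.52 log units; beyond the scatter). For compound 3 the expected value is 30000 nM, with an estimated range from 5000 nM to 100000 nM.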

Compound 3, concentration for 50% growth inhibition: > 100000 nM
Compound 3 was reported as a limit (the forecaster's own chance of this, stated with the estimate: 30%); at least 3.3-fold (0.52 log units) between middle value and limit.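

In this assay compound 3 gives > 100000 nM, which is a limit of the assay and not a number. Set against compound 1, the new ring gives a readable result, an at least 4.0-fold higher number from compound 1 to compound 3 (0.60 log units; beyond the scatter), so among the three rings shown only the 4-fluoro-3-methylphenyl of compound 1 brings a measurable number in this place. The step that joins compound 2 and compound 3 cannot be read, as both ends are limits, so the 2,4,6-trihydroxyphenyl and 4-(dimethylamino)phenyl rings cannot be put in order, even though they differ in their hydrogen-bond donors and acceptors, and the new result adds a second, quite different ring at the same limit: the limit of > 100000 nM in this assay, at which 2 of the 3 values shown sit.

Still open, as far as these compounds go, is whether the measurable number of compound 1 goes with its fluorine, its methyl or the two together, and how a plain phenyl ring, a ring with a single hydroxyl or one carrying a carboxylic acid would read out in this place. Also open, from the compounds shown here alone, is whether this place would respond in the same way with an amine elsewhere on the shared core.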